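Series notes: phenyl to alkyl at the chain terminus

A few compounds are considered here, and "the series" means these few. Any claim that something is new, unique, unknown or untested is made for them only; others in the source may bear on it.

Going by the values given here, compound 1 `Nc1n/c(=N\CCCCc2ccccc2)nc(N)c2c1ncn2Cc1ccccc1` is the weaker of the two measured compounds in a functional assay on OVCAR-3 cells (Homo sapiens) for antiproliferative activity, read by WST assay, with a stated time of 72 h (on this read-out lower numbers stand for stronger inhibition and higher numbers for weaker inhibition), where compound 1 gives 37300 nM and its only neighbour, compound 2 `CCCCCCCCCCCCCC/N=c1\nc(N)c2ncn(Cc3ccccc3)c2c(N)n1`, gives 5500 nM. Compound 3 `CCCCCCCCCC/N=c1\nc(N)c2ncn(Cc3ccccc3)c2c(N)n1` differs from compound 1 in one place: hexyl in place of phenyl on a saturated chain carbon, four bonds along the chain from a double-bonded nitrogen. Among the compounds with values here, the one step that bears on this change is a 6.8-fold lower number from compound 1 to compound 2 (0.83 log units; beyond the scatter), where the same position carries decyl instead of hexyl. Within the data shown here, only this single step is available, and no second example tests whether a shorter alkyl group behaves like the longer one, so the expected step for compound 3 is taken as smaller than that of compound 2 but still beyond the scatter, in the direction of a lower number. On that basis compound 3 is expected to show a 3.1-fold lower number from compound 1 to compound 3 (0.49 log units; beyond the scatter) in this assay. The estimate for compound 3 is 12000 nM, with a range from 4500 nM to 32000 nM.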

Compound 3, half-maximal inhibitory concentration: 3950 nM
Beside the measured number, compound 3's estimate is 3.0-fold (0.48 log units) above it, outside the stated range (below it).
By their numbers in this assay, from the lowest: compounds 3 and 2 (each within the scatter of the next); then compound 1.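

In this assay, going by these compounds alone, hexyl in place of phenyl on a saturated chain carbon, four bonds along the chain from a double-bonded nitrogen, gives a 9.4-fold lower number from compound 1 to compound 3 (0.98 log units; beyond the scatter) and so shows that the advantage of an alkyl end over phenyl, until now seen only with decyl, also holds with hexyl. Hydrogen in place of butyl on a saturated chain carbon gives a 1.4-fold lower number from compound 2 to compound 3 (0.14 log units; within the scatter) and so leaves compound 2 and compound 3 indistinguishable on this read-out, with no dependence on chain length visible across this span. No measurement at hand accounts for the difference between the phenyl end and the alkyl ends.

Open, from the compounds shown here alone, is whether an alkyl end shorter than hexyl, such as ethyl, keeps this level. Also open, going by these compounds, is how a longer chain, or a chain ending in an amine or a carboxylic acid, would compare.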